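The compounds below may be only part of what the source reports. "The series", "measured", "known", "first", "only" and "open" are said of these compounds alone.

Working notes on the series. Compound 1 `O=C(Nc1c(C(O)(C(F)(F)F)C(F)(F)F)ccc2ccccc12)c1ccco1` and compound 2 `O=C(Nc1c(C(O)(C(F)(F)F)C(F)(F)F)ccc2ccccc12)c1cnco1` share one core and differ only in the ring on the carbonyl carbon. In an assay on LtK cells with ATP-sensitive inward rectifier potassium channel 11 (Homo sapiens) as the target (on this read-out lower numbers stand for an effect already at smaller amounts and higher numbers for an effect only at larger amounts of compound), compound 1 gives 9 nM; in this assay compound 2 gives 24 nM. For the measured compounds named here, of the two numbers known so far, compound 2 stands at the higher one, and the single measured step is a 2.7-fold higher number from compound 1 to compound 2 (0.43 log units; beyond the scatter). Compound 3 `O=C(Nc1c(C(O)(C(F)(F)F)C(F)(F)F)ccc2ccccc12)c1cccnc1` is not yet measured; it differs from compound 2 thus: pyridin-3-yl in place of 1,3-oxazol-5-yl on a carbonyl carbon. Going by the values given here, the only measured step that bears on this change is the one above, and it exchanges one five-membered ring for another at the same carbonyl carbon, so it speaks to the size of ring swaps here but not to the direction of this particular one. For compound 3 in this assay the expected step is a 1.0-fold higher number from compound 2 to compound 3 (0.02 log units; within the scatter), with no direction firmly indicated beyond the scatter. The estimate for compound 3 is 25 nM, in a range from 8 nM to 80 nM.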

Compound 3, half-maximal effective concentration: 60 nM
Compound 3: the middle estimate sits 2.4-fold (0.38 log units) below what was measured; the range from low to high includes it.
By their numbers in this assay, from the lowest: compound 1; then compound 2; then compound 3.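

In this assay, the ring on the carbonyl carbon can also be six-membered, and the step of a 2.5-fold higher number from compound 2 to compound 3 (0.40 log units; beyond the scatter) is beyond the scatter, whereas the earlier ring swap compared only five-membered rings. Taken against the furan-2-yl ring, pyridin-3-yl gives a 6.7-fold higher number from compound 1 to compound 3 (0.82 log units; beyond the scatter) and is the largest step so far, so among these three compounds the one six-membered ring carries the highest number, with compound 1 lowest and compound 2 in the middle. Nothing on hand accounts for this rise.

With a single six-membered ring, ring size cannot be separated from the identity and placement of the ring atoms here. Open, as far as these compounds go, are how a plain phenyl ring, pyridin-4-yl or a saturated piperidine ring would read at this carbonyl carbon, and whether an amine on the ring would shift the number.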